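Working notes: from compound 3 to compound 4

The source may report more compounds than this note shows. Statements on the series, on what has been measured and on what is new or still open speak of the compounds shown alone.

In a functional assay on U-87MG ATCC cells for antiproliferative activity against U-87 MG (Homo sapiens), read by MTT assay, with a stated time of 48 h (on this read-out higher numbers stand for weaker inhibition and lower numbers for stronger inhibition), compound 3 `C/C(=C\CC/C(C)=C/CC[C@@H]1[C@@]2(C)CCC(=O)C(C)(C)[C@H]2CC[C@@]1(C)O)CC/C=C(\C)C(=O)OCc1cn(-c2ccc(C(C)(C)C)cc2)nn1` reads > 150000 nM, which is a limit of the assay and not a number. Compound 1 `C#CCOC(=O)/C(C)=C/CC/C(C)=C/CC/C(C)=C/CC[C@@H]1[C@@]2(C)CCC(=O)C(C)(C)[C@H]2CC[C@@]1(C)O` reads > 150000 nM, and this too is a limit of the assay. Compound 2 `C/C(=C\CC/C(C)=C/CC[C@@H]1[C@@]2(C)CCC(=O)C(C)(C)[C@H]2CC[C@@]1(C)O)CC/C=C(\C)C(=O)OCc1cn(-c2cccc(Br)c2)nn1` is the only one of the three with a number, at 8750000 nM. Among the measured compounds shown here, the series so far is summed up by the limit of > 150000 nM in this assay, at which 2 of the 3 values shown sit.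

The next member is compound 4 `C/C(=C\CC/C(C)=C/CC[C@@H]1[C@@]2(C)CCC(=O)C(C)(C)[C@H]2CC[C@@]1(C)O)CC/C=C(\C)C(=O)OCc1cn(-c2cccc(O)c2)nn1`, with 3-hydroxyphenyl in place of 4-(tert-butyl)phenyl on an aromatic nitrogen. For the measured compounds named here, two measured steps bear on this change. Going by the values given here, the first is a step that the limit leaves unreadable from compound 1 to compound 2, which brings in the aromatic group. The second is a step that the limit leaves unreadable from compound 2 to compound 3, which exchanges that group on the same aromatic nitrogen and is the closer precedent. Neither step has a readable size, so neither sets a direction for the new exchange.

No firm direction can therefore be expected in this assay, and compound 4 is expected to stay in the same region as the three measured compounds. The expected change is a step that the limit leaves unreadable from compound 3 to compound 4, and this estimate is a loose one. Compound 4 is estimated at 200000 nM, with an expected range from 30000 nM to 2000000 nM.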

Compound 4, half-maximal inhibitory concentration: > 150000 nM
Compound 4: a limit, no number; the forecaster's own chance of this, stated with the estimate: 50%; the middle value lies beyond the limit too.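

In this assay compound 4 gives > 150000 nM, which is a limit of the assay and not a number, so the steps joining compound 4 to compound 1, compound 2 and compound 3 cannot be read. The compounds shown leave open whether any exchange of the group on the aromatic nitrogen changes this read-out: the limit of > 150000 nM in this assay, at which 3 of the 4 values shown sit.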